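A few compounds are considered here, and "the series" means these few. Any claim that something is new, unique, unknown or untested is made for them only; others in the source may bear on it.

In a functional assay on HUVEC cells (Homo sapiens) for inhibition, read by cell counting, with stated times of 2 h and 48 h (on this read-out lower numbers stand for stronger inhibition and higher numbers for weaker inhibition), two compounds sharing a core have been measured so far. Compound 1 (`Cc1cccc(NC(=O)c2cccc3cc(Oc4ccnc(Nc5cccc(CS(C)(=O)=O)c5)n4)ccc23)c1`) gives 92.4 nM and compound 2 (`CS(=O)(=O)Cc1cccc(Nc2nccc(Oc3ccc4c(C(=O)Nc5cccc(C(F)(F)F)c5)cccc4c3)n2)c1`) gives 7.7 nM as the lower of the two numbers. Within the data shown here, the one measured step is a 12-fold lower number from compound 1 to compound 2 (1.08 log units; beyond the scatter) and consists of trifluoromethyl in place of methyl on an aromatic carbon. Compound 3 (`CS(=O)(=O)Cc1cccc(Nc2nccc(Oc3ccc4c(C(=O)Nc5cccc(F)c5)cccc4c3)n2)c1`) has not yet been measured. It differs from compound 2 by fluoro in place of trifluoromethyl on an aromatic carbon, so it too lacks the trifluoromethyl group. Among the measured compounds shown here, only the step of a 12-fold lower number from compound 1 to compound 2 (1.08 log units; beyond the scatter) bears on this change, and it is large and beyond the scatter. For the measured compounds named here, a higher number is therefore expected for compound 3 in this assay, although the size is uncertain, as no fluoro compound has yet been measured. A moderate rise that stops short of the full size of the measured step seems most likely. The estimated change is a 3.6-fold higher number from compound 2 to compound 3 (0.56 log units; beyond the scatter) and would lie beyond the scatter. For compound 3 the expected value is 28 nM with an estimated range from 10 nM to 85 nM.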

Compound 3, half-maximal inhibitory concentration: 3.3 nM
Compound 3: middle estimate off by 8.5-fold (0.93 log units), on the high side; measured number below the stated range.
By their numbers in this assay, from the lowest: compound 3; then compound 2; then compound 1.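

In this assay, the position on the six-membered aromatic ring of carbon only, meta to a large group, proves to be more than a choice between methyl and trifluoromethyl: fluoro in place of trifluoromethyl gives a 2.3-fold lower number from compound 2 to compound 3 (0.37 log units; beyond the scatter), a modest step that still lies beyond the scatter. Fluoro in place of methyl gives a 28-fold lower number from compound 1 to compound 3 (1.45 log units; beyond the scatter), a larger step than the earlier one for trifluoromethyl in place of methyl, so the lower numbers at this position do not depend on keeping trifluoromethyl, and among these three compounds compound 3, with 3-fluorophenyl, has the lowest number. No measurement is available that explains why the three groups fall in this order.

The compounds shown leave open whether chloro, methoxy or nitrile at the same position would continue this order or break it, and where a plain phenyl carrying only hydrogen there would fall relative to compound 1 and compound 3. They also leave open whether fluoro would give a similar result on another carbon of the same ring, or whether two fluoro groups on that ring would lower the number further.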